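The source may hold more compounds than are shown below. What is called first, only, known or untested is meant among the compounds shown, and "the series" means these compounds.

In a physicochemical assay for solubility, measured as kinetic solubility (on this read-out lower numbers stand for lower solubility and higher numbers for higher solubility), compound 1 (`Nc1nc(-n2cc(C(=O)O)c(=O)c3cc(F)c([C@H]4C[C@H](O)C4)c(Cl)c32)c(F)cc1F`) gives 59300 nM and compound 2 (`Nc1nc(-n2cc(C(=O)O)c(=O)c3cc(F)c([C@H]4C[C@@H](O)C4)c(Cl)c32)c(F)cc1F`) gives 44800 nM, so the two stand level. Among the measured compounds shown here, the only measured step, a 1.3-fold lower number from compound 1 to compound 2 (0.12 log units; within the scatter), is a matter of configuration alone (the fact that compounds 1 and 2 differ only in the configuration as drawn) and does not exchange the group at issue. Compound 3 (`Nc1nc(-n2cc(C(=O)O)c(=O)c3cc(F)c(N4CC(N)C4)c(Cl)c32)c(F)cc1F`) carries 3-aminoazetidin-1-yl in place of 3-hydroxycyclobutyl on an aromatic carbon. For the measured compounds named here, with no measured precedent for this exchange, the expectation rests on compound 2 at 44800 nM. The expected change is none beyond the scatter, an estimated 1.1-fold higher number from compound 2 to compound 3 (0.05 log units; within the scatter). The estimate for compound 3 is 50000 nM, with an expected range of 18000 nM to 140000 nM.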

Compound 3, solubility: 3600 nM
Estimate against measurement, compound 3: 14-fold (1.14 log units) above, and the stated range ends above it.
By their numbers in this assay, from the lowest: compound 3; then compounds 2 and 1 (each within the scatter of the next).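

In this assay the aromatic carbon ortho to a chloro group and ortho to a fluoro group proves sensitive to what it carries: 3-aminoazetidin-1-yl in place of 3-hydroxycyclobutyl gives a 12-fold lower number from compound 2 to compound 3 (1.09 log units; beyond the scatter) and a 16-fold lower number from compound 1 to compound 3 (1.22 log units; beyond the scatter). Both rings bring 5 heavy atoms, yet this exchange moves the number where the change of configuration between compound 1 and compound 2 did not. Nothing measured here gives a cause for the drop.

Open, as far as these compounds go, is whether the ring nitrogen or the amino group carries the step. Also open, from the compounds shown here alone, is how 3-hydroxyazetidin-1-yl or an open-chain amine would read at this position.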